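The source may report more compounds than this note shows. Statements on the series, on what has been measured and on what is new or still open speak of the compounds shown alone.

Compound 1 `c1ccc(-c2ccoc2)c(OCC2=NCCN2)c1`: 5.01 nM
Compound 2 `Cc1cc(-c2ccccc2OCC2=NCCN2)sn1`: < 100000 nM

In a functional assay for activation of Alpha-1D adrenergic receptor (Homo sapiens), read by calcium flux (a higher number here means that more compound is needed for the effect, a lower number that less compound is needed), compound 1 gives 5.01 nM. For compound 2 this assay reports only a limit, < 100000 nM. The step that the limit leaves unreadable from compound 1 to compound 2 therefore cannot be sized, because of the limit of < 100000 nM in this assay, at which 1 of the 2 values shown sits.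

Compound 3 `Cc1cnsc1-c1ccccc1OCC1=NCCN1` has not yet been measured in this assay; it differs from compound 2 by 4-methyl-1,2-thiazol-5-yl in place of 3-methyl-1,2-thiazol-5-yl on an aromatic carbon. For the measured compounds named here, the one measured step in this assay is unreadable, so no measured step sizes a shift of a methyl group on the thiazole ring. Compound 3 is expected to remain weak, with a step that the limit leaves unreadable from compound 2 to compound 3 within scatter. Compound 3 is estimated at 50000 nM, between 5000 nM and 200000 nM.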

Compound 3, half-maximal effective concentration: < 100000 nM
Compound 3: no number, only a limit; the forecaster's own chance of this, stated with the estimate: 70%; the middle value is on the limit's open side.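

In this assay compound 3 gives only a limit, < 100000 nM. No step from compound 1 or compound 2 to compound 3 can be read, because these values are bounded by a limit: the limit of < 100000 nM in this assay, at which 2 of the 3 values shown sit.

The compounds shown leave open whether 4-methyl-1,2-thiazol-5-yl and 3-methyl-1,2-thiazol-5-yl differ at all in this read-out.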